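Methoxy for hydrogen on a shared core: working notes

This account rests on a few compounds, and the source may have more. Where it says the series, first, only, none or still open, it means among the compounds named here.

Measured so far:
- compound 1 `COc1ccc(Nc2nc(N)c(C(=O)c3ccc(OC)c(OC)c3)s2)cc1`; in a functional assay on MOLT-4 cells (Homo sapiens) for antiproliferative activity, read by cell counting, with a stated time of 2 days (on this read-out higher numbers stand for weaker inhibition and lower numbers for stronger inhibition), compound 1 gives 37 nM
- compound 2 `COc1ccc(Nc2nc(N)c(C(=O)c3cc(OC)c(OC)c(OC)c3)s2)cc1`; in this assay compound 2 gives 480 nM
- compound 3 `Nc1nc(Nc2ccc(F)cc2)sc1C(=O)c1ccccc1`; in this assay compound 3 reaches only a limit of the assay, > 10000 nM

Compound 1 and compound 2 differ in one place: methoxy in place of hydrogen on an aromatic carbon. That single change gave a 13-fold higher number from compound 1 to compound 2 (1.11 log units; beyond the scatter). Among the measured compounds shown here, compound 3 is the weak member of the set; its value is a limit and not a number, and it is the one value sitting at the limit of > 10000 nM in this assay, at which 1 of the 3 values shown sits. Compound 3 and compound 1 differ in more than one place, and the difference between the two cores is not broken down here.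

Compound 4 `COc1ccc(C(=O)c2sc(Nc3ccc(F)cc3)nc2N)cc1` has not yet been measured. It differs from compound 3 by methoxy in place of hydrogen on an aromatic carbon. For the measured compounds named here, this is the same kind of change as the one from compound 1 to compound 2, but not the same: in compound 4 the entering methoxy sits para to a large group, whereas in compound 2 it sits ortho to a methoxy group, meta to a large group and meta to a methoxy group. Going by the values given here, the one measured step of this kind weakened inhibition, yet its surroundings differ from those in compound 4, and the starting point, compound 3, is known only as a limit. The expectation is therefore loose. The step is estimated at an at least 2.0-fold lower number from compound 3 to compound 4 (0.30 log units; that floor lies within the scatter), resting on the limit for compound 3 and on the weakening seen in a 13-fold higher number from compound 1 to compound 2 (1.11 log units; beyond the scatter) read against the differing place. For compound 4 in this assay the estimate is 5000 nM, expected to fall between 800 nM and 30000 nM.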

Compound 4, half-maximal inhibitory concentration: > 10000 nM
Compound 4 was reported as a limit (the forecaster's own chance of this, stated with the estimate: 40%); middle value at least 2.0-fold (0.30 log units) from the limit.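

Compound 3 and compound 4 both stand at a limit in this assay, so the step from phenyl to 4-methoxyphenyl cannot be read: the limit of > 10000 nM in this assay, at which 2 of the 4 values shown sit.

The compounds shown leave open whether methoxy in place of hydrogen on an aromatic carbon changes inhibition at all on the core of compound 3, where neither value is a number.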